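The source may hold more compounds than are shown below. What is called first, only, known or untested is meant among the compounds shown, and "the series" means these compounds.

Measured in a functional assay on NCI-H460 cells (Homo sapiens); a lower number here means that less compound is needed, a higher number that more compound is needed for the effect:

compound 1 `COc1cc(C2OC(c3ccc(N(C)C)cc3)=NN2C(C)=O)cc(OC)c1OC` gives 0.044 uM
compound 2 `COc1cc(C2OC(c3ccccc3N(C)C)=NN2C(C)=O)cc(OC)c1OC` gives 109 uM
compound 3 `COc1ccc(C2OC(c3ccc(N(C)C)cc3)=NN2C(C)=O)c(OC)c1OC` gives 6.8 uM

Compound 3 stands in the middle of these numbers, well above compound 1 and well below compound 2. The next structure is compound 4 `COc1ccc(C2OC(c3ccc(N(C)C)cc3)=NN2C(C)=O)cc1OC`. It differs from compound 3 by one change: hydrogen in place of methoxy on an aromatic carbon.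

Among the measured compounds shown here, no measured step makes this exact change. For the measured compounds named here, the one measured step, a 2500-fold higher number from compound 1 to compound 2 (3.39 log units; beyond the scatter), lies on the other ring, and it shows only that moving a group can matter greatly. More relevant is that compound 4 has no methoxy at the carbon concerned, and neither does compound 1 at 0.044 uM. However, compound 4 also lacks another methoxy that compound 1 carries, so a full drop to that value seems unlikely. The expected change is a 3.4-fold lower number from compound 3 to compound 4 (0.53 log units; beyond the scatter), a moderate move towards a lower number and an uncertain one. For compound 4 the estimated value is 2 uM, with an expected range from 0.3 uM to 15 uM.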

Compound 4, concentration for half-maximal effect: 5.1 uM
The estimate for compound 4 lay 2.6-fold (0.41 log units) below the measured number; measured number inside the range.
By their numbers in this assay, from the lowest: compound 1; then compounds 4 and 3 (each within the scatter of the next); then compound 2.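

In this assay the methoxy ortho to a large group and ortho to a methoxy group can give way to hydrogen with no readable effect, as a 1.3-fold lower number from compound 3 to compound 4 (0.12 log units; within the scatter) shows. The same kind of swap at a different methoxy is far from silent: a 120-fold higher number from compound 1 to compound 4 (2.06 log units; beyond the scatter) is a large step. Among the compounds shown here, in these compounds, then, what hydrogen in place of methoxy does depends on which methoxy leaves, and the methoxy that compound 1 carries and compound 4 lacks counts for far more than the one lost from compound 3.

Still open, going by these compounds, is how this position would respond to other groups, such as a hydroxyl, an amine or a longer chain like ethoxy. Nothing shown here explains why the two methoxy groups differ so much.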